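The compounds below may be only part of what the source reports. "The series", "measured", "known", "first", "only" and "open" are said of these compounds alone.

In an ADME assay on the whole organism with Oryza sativa as the target, tested at 1 uM (on this read-out lower numbers stand for a stronger effect and higher numbers for a weaker effect at the one concentration tested), compound 3 `C[C@H](NC(=O)Nc1ccccc1F)c1ccccc1` gives 92% and stands lowest of the three numbers, though both gaps are within the scatter: compound 1 `C[C@H](NC(=O)Nc1ccccc1C(F)(F)F)c1ccccc1` gives 98% and compound 2 `CC(=O)c1ccccc1NC(=O)N[C@@H](C)c1ccccc1` gives 97%. Compound 4 `C[C@H](NC(=O)Nc1ccccc1Br)c1ccccc1` differs from compound 3 by bromo in place of fluoro on an aromatic carbon. Going by the values given here, the steps that bear on it are those at the same aromatic carbon: a number 6 percentage points lower from compound 1 to compound 3 (within the scatter) and a number 5 percentage points lower from compound 2 to compound 3 (within the scatter), with a number 1 percentage points lower from compound 1 to compound 2 (within the scatter) showing the same picture. Three different groups at this position leave this assay essentially unchanged, so no step beyond the scatter is expected from compound 3 to compound 4, a number 2 percentage points higher from compound 3 to compound 4 (within the scatter) being the expected change. Compound 4 is therefore estimated at 94%, with a range of 84% to 100%.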

Compound 4, a percentage reported as activity, at one concentration (the size of the read-out at that concentration, not a potency): 99%
The estimate for compound 4 lay 5 percentage points below the measured number; low and high end bracket the measured number.
By their numbers in this assay, from the lowest: compounds 3, 2, 1 and 4 (each within the scatter of the next).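

In this assay, bromo adds a fourth group at this aromatic carbon, ortho to a large group, and no step beyond the scatter appears: a number 7 percentage points higher from compound 3 to compound 4 (within the scatter) and a number 2 percentage points higher from compound 2 to compound 4 (within the scatter) and a number 1 percentage points higher from compound 1 to compound 4 (within the scatter). Fluoro, bromo, trifluoromethyl and acetyl at this position therefore cannot be told apart on this read-out. No evidence at hand bears on this result. On these data alone, whether an amine, a carboxylic acid or a longer chain here would give a step beyond the scatter remains open, as does the effect of any change elsewhere on the shared core.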